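Chain extension from compound 2 to compound 3

The compounds below may be only part of what the source reports. "The series", "measured", "known", "first", "only" and "open" are said of these compounds alone.

Compound 2 `CSc1nc(NCCCc2ccccc2)c2ccccc2n1` shows the highest number of the two measured in a functional assay on HTB-54 cells (Homo sapiens) for cytotoxicity, read by MTT assay, with a stated time of 72 h (on this read-out higher numbers stand for weaker inhibition of growth and lower numbers for stronger inhibition of growth), giving 50600 nM. Compound 1 `CCCCC[Se]c1nc([Se]CCCCC)c2cccnc2n1` gives 15200 nM in this assay, a lower number beyond the usual scatter. Compound 3 `CSc1nc(NCCCCc2ccccc2)c2ccccc2n1` differs from compound 2 by benzyl in place of phenyl on a saturated chain carbon, three bonds along the chain from a nitrogen on an aromatic ring. For the measured compounds named here, no measured pair shows this change, so the step is expected to be small, within the scatter, in either direction. The step is estimated as a 1.3-fold lower number from compound 2 to compound 3 (0.10 log units; within the scatter). Compound 3 is expected to give about 40000 nM in this assay, within a range from 15000 nM to 110000 nM.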

Compound 3, concentration for 50% growth inhibition: > 100000 nM
Compound 3 was reported as a limit; the forecaster's own chance of this, stated with the estimate: 10%; middle value at least 2.5-fold (0.39 log units) away from the limit.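

In this assay compound 3 is reported only as a limit, so this first pair at the position has no exact size: the limit of > 100000 nM in this assay, at which 1 of the 3 values shown sits. Benzyl in place of phenyl on this saturated chain carbon gives an at least 1.9-fold higher number from compound 2 to compound 3 (0.29 log units; that floor lies within the scatter). The change therefore gives no sign of stronger inhibition of growth, though the limit cannot show whether the real gap lies beyond the scatter.

The compounds shown leave open whether a longer chain would behave like benzyl here. They also leave open how an amine or a carboxylic acid at this place would read.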